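The source may hold more compounds than are shown below. What is called first, only, known or untested is meant among the compounds shown, and "the series" means these compounds.

In a functional assay on A2780 cells (Homo sapiens) for antiproliferative activity, read by CellTiter-Glo, with a stated time of 72 h (a lower number here means a stronger inhibitor, a higher number a weaker inhibitor), compound 1 `C[C@H](NC(=O)c1cccc(F)c1)c1ccc(NC(=O)N2CC(c3cccnc3)C2)cc1` gives 2.3 nM, while compound 2 `C[C@H](NC(=O)c1ncccn1)c1ccc(NC(=O)N2CC(c3cccnc3)C2)cc1` gives 36 nM, the higher of the two numbers and so the weaker result. Among the measured compounds shown here, the only measured step, a 16-fold higher number from compound 1 to compound 2 (1.19 log units; beyond the scatter), placed pyrimidin-2-yl in place of 3-fluorophenyl on a carbonyl carbon. It was large, which shows that the number in this assay can respond strongly to a change at this place. Compound 3 `C[C@H](NC(=O)[C@@H]1CCCN1C)c1ccc(NC(=O)N2CC(c3cccnc3)C2)cc1` is altered at the same place: 1-methylpyrrolidin-2-yl in place of pyrimidin-2-yl on a carbonyl carbon. Both groups measured here are aromatic rings, so the data offer no direct guide to a non-aromatic ring such as 1-methylpyrrolidin-2-yl. A small rise in the number is expected, though with wide uncertainty in either direction. The estimated change is a 1.7-fold higher number from compound 2 to compound 3 (0.22 log units; within the scatter). For compound 3, the expected value is 60 nM, within an estimated range of 12 nM to 300 nM.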

Compound 3, half-maximal inhibitory concentration: 5.7 nM
Compound 3: the middle estimate sits 11-fold (1.02 log units) above what was measured; measured number below the stated range.
By their numbers in this assay, from the lowest: compound 1; then compound 3; then compound 2.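

Swapping the aromatic pyrimidin-2-yl for the non-aromatic 1-methylpyrrolidin-2-yl gave a 6.3-fold lower number from compound 2 to compound 3 (0.80 log units; beyond the scatter) in this assay and so shows that a low number at this position on the carbonyl carbon does not depend on an aromatic ring. The 3-fluorophenyl group still gives the lowest number of the three, and a 2.5-fold higher number from compound 1 to compound 3 (0.39 log units; beyond the scatter) shows that the non-aromatic ring closes much of the gap opened by pyrimidin-2-yl but not all of it. Nothing available explains why the three groups fall in this order.

As far as these compounds go, only one stereo form of the 1-methylpyrrolidin-2-yl group appears here, so the effect of its defined stereocentre remains open. It is also unknown how the number would respond to the same ring without its methyl group, to a piperidin-2-yl ring or to an open-chain amine such as dimethylaminomethyl.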